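The source may hold more compounds than are shown below. What is called first, only, known or untested is meant among the compounds shown, and "the series" means these compounds.

Compound 1 `O=C(N[C@@H](CO)C(=O)NO)c1ccc(C#Cc2ccccc2)cc1` is a hydroxamic acid built on a serine-like piece attached to the shared core. In a physicochemical assay for solubility (on this read-out higher numbers stand for higher solubility and lower numbers for lower solubility), compound 1 gives 28000 nM, which places it second highest of the three measured compounds. Compound 2 `COCCNC(=O)C[C@H](NC(=O)c1ccc(C#Cc2ccccc2)cc1)C(=O)NO` gives 78000 nM, and compound 3 `CS(=O)(=O)C[C@H](NC(=O)c1ccc(C#Cc2ccccc2)cc1)C(=O)NO` gives 2000 nM. The step of a 2.8-fold higher number from compound 1 to compound 2 (0.44 log units; beyond the scatter) is modest, while the step of a 14-fold lower number from compound 1 to compound 3 (1.15 log units; beyond the scatter) and the step of a 39-fold lower number from compound 2 to compound 3 (1.59 log units; beyond the scatter) are both large.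

Compound 4 `O=C(CNC(=O)c1ccc(C#Cc2ccccc2)cc1)NO` differs from compound 1 by a single change (hydrogen in place of hydroxymethyl on a saturated chain carbon bound to an amide-type nitrogen and a carbonyl carbon). Among the compounds with values here, none of the measured steps removes a group at this carbon outright; all three swap one group for another, so they only show that this position can move this assay in either direction by a large amount. A small loss of a group that carries both a hydrogen-bond donor and acceptor gives no clear precedent here, so a small downward step is expected, and for compound 4 the estimate is 15000 nM, within 5000 nM to 45000 nM, meaning an expected step of a 1.9-fold lower number from compound 1 to compound 4 (0.27 log units; within the scatter).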

Compound 4, solubility: 21000 nM
Estimate against measurement, compound 4: 1.4-fold (0.15 log units) below, within the range that was stated.
By their numbers in this assay, from the lowest: compound 3; then compounds 4 and 1 (each within the scatter of the next); then compound 2.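

Replacing hydroxymethyl with hydrogen on this saturated chain carbon gives a step within the scatter (a 1.3-fold lower number from compound 1 to compound 4 (0.12 log units; within the scatter)), so in this assay these two groups cannot be told apart. Compound 4 also gives the earlier group swaps a reference point with no side chain at this carbon. Hydrogen in place of (methylsulfonyl)methyl gives one large step (an 11-fold higher number from compound 3 to compound 4 (1.02 log units; beyond the scatter)), while hydrogen in place of ((2-methoxyethyl)carbamoyl)methyl gives a modest step the opposite way (a 3.7-fold lower number from compound 2 to compound 4 (0.57 log units; beyond the scatter)), so the side chains shown can put the number on either side of compound 4.

Still open, on these data alone, is where an amine, a carboxylic acid or a simple longer alkyl chain on this carbon would fall relative to compound 4. Nothing shown here explains the differences among these groups.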